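Aminoalkyl Replacement of the Sulfonium Chain on the Methylated Core

The source may hold more compounds than are shown below. What is called first, only, known or untested is meant among the compounds shown, and "the series" means these compounds.

Working notes on a small set of nucleoside analogues tested in an assay on isolated protein for inhibition of S-adenosylmethionine decarboxylase proenzyme (Homo sapiens); on this read-out lower numbers stand for stronger inhibition and higher numbers for weaker inhibition. Compound 1 `Cc1nc2c(N)ncnc2n1[C@@H]1O[C@H](CN(C)CCC(N)=O)[C@@H](O)[C@H]1O` gives 400 nM in this assay. Compound 2 `Cc1nc2c(N)ncnc2n1[C@@H]1O[C@H](C[S+](C)C)[C@@H](O)[C@H]1O` gives 3000 nM in this assay, the second highest of the three numbers in hand; its nearest neighbour is compound 1, while compound 3 lies far above it. Compound 3 `CN(CCCN)C[C@H]1O[C@@H](n2cnc3c(N)ncnc32)[C@H](O)[C@@H]1O`, which lacks the methyl on the shared core and carries a different chain, gives 500000 nM in this assay.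

For the measured compounds named here, the one single-point step is a 7.5-fold higher number from compound 1 to compound 2 (0.88 log units; beyond the scatter), where the sulfonium group replaces the amide-terminated aminoalkyl chain on the saturated chain carbon bound to a saturated ring carbon.

Compound 4 `Cc1nc2c(N)ncnc2n1[C@@H]1O[C@H](CN(C)CCN)[C@@H](O)[C@H]1O` is the next member. It differs from compound 2 by a group of 5 heavy atoms (3 carbon, 2 nitrogen; no ring) in place of a group of 3 heavy atoms (2 carbon, 1 sulfur; no ring), on a saturated chain carbon bound to a saturated ring carbon. Going by the values given here, this reverses the direction of the one measured step: a nitrogen-bearing chain again replaces the sulfonium group at the same place. The step from compound 1 to compound 2 is the only one that bears on it, and it was modest; compound 3 cannot be read onto this change since it differs from compound 2 in more than one place.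

A modest step downward is therefore expected, of about a 3.0-fold lower number from compound 2 to compound 4 (0.48 log units; beyond the scatter). Compound 4 is expected to give about 1000 nM in this assay, within a range of 200 nM to 10000 nM.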

Compound 4, half-maximal inhibitory concentration: 88000 nM
For compound 4 the middle estimate is 88-fold (1.94 log units) below the measured one; the whole stated range lies below it.
By their numbers in this assay, from the lowest: compound 1; then compound 2; then compound 4; then compound 3.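

In this assay, a nitrogen-bearing chain on the saturated chain carbon bound to a saturated ring carbon does not by itself improve on the sulfonium group: (2-aminoethyl)(methyl)amino in its place gives a 29-fold higher number from compound 2 to compound 4 (1.47 log units; beyond the scatter), so the step from the earlier pair does not carry over to every aminoalkyl chain. The end of the chain matters strongly here, since amino in place of carbamoyl on a saturated chain carbon, two bonds along the chain from an amine nitrogen, gives a 220-fold higher number from compound 1 to compound 4 (2.34 log units; beyond the scatter), and the sulfonium compound 2 now sits in order between the two nitrogen-bearing chains. No measurement at hand accounts for this loss.

The compounds shown do not separate the effect of the terminal group from that of the chain itself, and a carboxylic acid or a methyl ester at the chain end, or a longer chain ending in amino on the shared core, would bear on that. From the compounds shown here alone, compound 3 differs from compound 4 in more than one place, so the contribution of the methyl on the shared core also remains open.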